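This account rests on a few compounds, and the source may have more. Where it says the series, first, only, none or still open, it means among the compounds named here.

In a functional assay on MCF7 cells (Homo sapiens) for antiproliferative activity, read by MTT assay, with a stated time of 72 h (on this read-out higher numbers stand for weaker inhibition and lower numbers for stronger inhibition), compound 1 `C/C=C/C(=O)Nc1cccc(Oc2nc(Nc3ccn(C)n3)nc3c2CSCC3)c1` gives 40000 nM, compound 2 `C/C=C/C(=O)Nc1cccc(Oc2nc(Nc3cccc(OC)c3)nc3c2CSCC3)c1` gives 23400 nM and compound 3 `C=CC(=O)Nc1cccc(Oc2nc(Nc3cccc(C#N)c3)nc3c2CSCC3)c1` gives 21700 nM. Compound 3 therefore stands within the scatter of both others. Compound 4 `C/C=C/C(=O)Nc1cccc(Oc2nc(Nc3cccc(C#N)c3)nc3c2CSCC3)c1` carries prop-1-en-1-yl in place of vinyl on a carbonyl carbon. For the measured compounds named here, the one measured step, a 1.7-fold lower number from compound 1 to compound 2 (0.23 log units; within the scatter), lies within the scatter, but it concerns the group on the nitrogen and bears only indirectly on this change. Compound 1 and compound 2 already carry prop-1-en-1-yl at that carbonyl carbon, and their values are not separated from that of compound 3. No step beyond the scatter is therefore expected in this assay; the estimated step is a 1.3-fold higher number from compound 3 to compound 4 (0.11 log units; within the scatter). Compound 4 is estimated at 28000 nM, with an expected range of 15000 nM to 50000 nM.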

Compound 4, half-maximal inhibitory concentration: 21400 nM
Estimate against measurement, compound 4: 1.3-fold (0.12 log units) above; the measured number falls inside the stated range.
By their numbers in this assay, from the lowest: compounds 4, 3, 2 and 1 (each within the scatter of the next).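

The swap of prop-1-en-1-yl for vinyl on the carbonyl carbon gives a 1.0-fold lower number from compound 3 to compound 4 (0.01 log units; within the scatter) in this assay and so does not separate the two groups with 3-cyanophenyl held fixed. With prop-1-en-1-yl held fixed, the groups on the nitrogen also stay unseparated, at a 1.1-fold lower number from compound 2 to compound 4 (0.04 log units; within the scatter) for cyano in place of methoxy and a 1.9-fold lower number from compound 1 to compound 4 (0.27 log units; within the scatter) for 3-cyanophenyl in place of 1-methyl-1H-pyrazol-3-yl. No supporting measurement accompanies this result.

Open, from the compounds shown here alone, is whether an amine on the chain, or a longer chain on that carbonyl carbon, gives a step beyond the scatter in this assay on these cells.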